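Saturated ring swap from compound 2 to compound 3

The source may report more compounds than this note shows. Statements on the series, on what has been measured and on what is new or still open speak of the compounds shown alone.

compound 1 `O=C1Nc2c(C(F)(F)F)cccc2C1(c1ccc(O)cc1)N1CCCCC1` gives > 1000000 nM as a limit
compound 2 `O=C1Nc2c(C(F)(F)F)cccc2C1(c1ccc(O)cc1)N1CCCCCC1` gives > 1000000 nM as a limit
compound 3 `O=C1Nc2c(C(F)(F)F)cccc2C1(c1ccc(O)cc1)N1CCC(O)CC1` has no measurement yet

In a functional assay on MCF7 cells (Homo sapiens) for inhibition, read by resazurin assay, with a stated time of 24 h (a lower number here means a stronger inhibitor, a higher number a weaker inhibitor), compound 2 stands at > 1000000 nM as a limit and not a number. Compound 3 differs from it by 4-hydroxypiperidin-1-yl in place of azepan-1-yl on a saturated ring carbon on the shared core. For the measured compounds named here, the only measured step bearing on this is a step that the two limits leave unreadable from compound 1 to compound 2 and it offers no size to carry over. No step beyond the scatter is therefore expected in this assay in either direction, and the estimate means a number no higher from compound 2 to compound 3 (the limit leaves the size open) as the expected step. Compound 3 is estimated at 1000000 nM within a range from 200000 nM to 3000000 nM and is expected perhaps to give only a limit.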

Compound 3, half-maximal inhibitory concentration: > 1000000 nM
Compound 3 ended at the assay's limit; the forecaster's own chance of this, stated with the estimate: 70%; the middle value lies on the limit itself.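

No new step can be read among compound 1, compound 2 and compound 3 in this assay, because all three rest on one limit and not on numbers: the limit of > 1000000 nM in this assay, at which 3 of the 3 values shown sit.

On these data alone, whether these three saturated rings differ at all in this assay stays open, as does which change on the shared core would give a readable value.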